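This account rests on a few compounds, and the source may have more. Where it says the series, first, only, none or still open, it means among the compounds named here.

Working notes on the series. Compound 1 `O=c1c(-c2cccc([N+](=O)[O-])c2)nc2c(Cl)cccc2n1Cc1ccccc1` in an assay on cells for activation of Cystic fibrosis transmembrane conductance regulator (Homo sapiens), read by fluorescence, with a stated time of 10 min (a higher number here means that more compound is needed for the effect, a lower number that less compound is needed), gives 110 nM. Compound 2 `O=c1c(-c2cccc([N+](=O)[O-])c2)nc2cc(Cl)c(Cl)cc2n1Cc1ccccc1` returns only a limit of this assay, > 10000 nM. Compound 3 `Cn1c(=O)c(-c2cccc([N+](=O)[O-])c2)nc2ccccc21`, the starting point of the present step, likewise returns only a limit in this assay, > 10000 nM. Within the data shown here, compound 3 therefore stands at the limit of > 10000 nM in this assay, at which 2 of the 3 values shown sit, and compound 1 alone in the set supplies a measured number; no step between two measured compounds differing in a single place is available, so the size of any change has to be judged from the structural change itself.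

The step to compound 4 `O=c1c(-c2cccc([N+](=O)[O-])c2)nc2ccccc2n1Cc1ccccn1` is pyridin-2-yl in place of hydrogen on a saturated chain carbon bound to an aromatic nitrogen; read one bond further out, methyl becomes (pyridin-2-yl)methyl. With compound 3 at a limit, the only directions open in this assay are toward a lower number or no change beyond the scatter. Compound 1, which also carries an aromatic ring on the saturated chain carbon bound to the aromatic nitrogen, gives 110 nM and is the nearest guide, though it differs from compound 4 in more than one place. Compound 4 is expected to emerge from the limit into a measurable number, estimated at 1000 nM with a range of 200 nM to 8000 nM. The step this estimate implies is an at least 10-fold lower number from compound 3 to compound 4 (1.00 log units; beyond the scatter), with a real chance that only a limit is reported again.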

Compound 4, half-maximal effective concentration: 52 nM
The estimate for compound 4 lay 19-fold (1.28 log units) above the measured number; measured number outside the range, below it.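

In this assay, among these compounds, the change from methyl to (pyridin-2-yl)methyl on the aromatic nitrogen gives an at least 190-fold lower number from compound 3 to compound 4 (2.28 log units; beyond the scatter), the first step that can be read at a single place. It shows that this position is highly sensitive to what it carries, and that the core of compound 4 reaches a measured number with no chloro group on it. The size of the step is only a minimum, because compound 3 returns a limit of the assay and not a number: the limit of > 10000 nM in this assay, at which 2 of the 4 values shown sit.

What the pyridin-2-yl ring contributes as such stays open: compound 1 differs from compound 4 in more than one place, so the ring nitrogen cannot be weighed against a plain phenyl ring, and no cause for the step can be read from these compounds. Also open, on these data alone, is how the number would respond to pyridin-3-yl or pyridin-4-yl in place of pyridin-2-yl, to a longer chain between the aromatic nitrogen and the ring, or to an amine or a carboxylic acid at this position.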